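Swapping the pyridine attachment point on compound 2

A few compounds are considered here, and "the series" means these few. Any claim that something is new, unique, unknown or untested is made for them only; others in the source may bear on it.

Measured compounds:
Compound 1, `OC[C@@H](O[C@H]1CCCN(Cc2ncc[nH]2)[C@H]1c1ccccc1)c1cc(Cl)cc(Cl)c1`, in an assay on isolated protein for activation of cGMP-dependent protein kinase 1 (Homo sapiens), read by ADP-Glo, with stated times of 120 min and 40 min (on this read-out lower numbers stand for an effect already at smaller amounts and higher numbers for an effect only at larger amounts of compound), gives 7000 nM.
Compound 2, `Clc1cc(Cl)cc(CO[C@H]2CCCN(Cc3cccnc3)[C@H]2c2ccccc2)c1`, in this assay gives 112000 nM.
Compound 3, `OC[C@@H](O[C@H]1CCCN(Cc2ccccc2Cc2nnco2)[C@H]1c1ccccc1)c1cc(Cl)cc(Cl)c1`, in this assay gives 3700 nM.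

Among these three, compound 2 shows the highest number in this assay; compound 1 sits nearest to it, compound 3 furthest, and both gaps lie beyond the scatter. Compound 4, `Clc1cc(Cl)cc(CO[C@H]2CCCN(Cc3ccncc3)[C@H]2c2ccccc2)c1`, has not yet been measured. It differs from compound 2 by pyridin-4-yl in place of pyridin-3-yl on a saturated chain carbon bound to an amine nitrogen in a ring; the two have the same atoms, joined differently.

Within the data shown here, only one step between measured compounds concerns the group on this saturated chain carbon bound to the amine nitrogen in the ring: a 1.9-fold lower number from compound 1 to compound 3 (0.28 log units; within the scatter). That step replaces the group with a very different one and still stays within the scatter, so the record offers nothing that moves a change of this kind clearly in either direction. The step from compound 2 to compound 4 is therefore expected to be a 1.0-fold lower number from compound 2 to compound 4 (0.01 log units; within the scatter), that is, none beyond the scatter. For compound 4 the estimated value in this assay is 110000 nM, with a range from 40000 nM to 300000 nM.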

Compound 4, half-maximal effective concentration: > 200000 nM
Compound 4 was reported as a limit; the forecaster's own chance of this, stated with the estimate: 25%; at least 1.8-fold (0.25 log units) between middle value and limit.
By their numbers in this assay, from the lowest: compounds 3 and 1 (each within the scatter of the next); then compound 2. At a limit, above all of these: compound 4.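

In this assay compound 4 gives > 200000 nM, which is a limit of the assay and not a number. Exchanging pyridin-3-yl for pyridin-4-yl on a saturated chain carbon bound to an amine nitrogen in a ring gives an at least 1.7-fold higher number from compound 2 to compound 4 (0.25 log units; that floor lies within the scatter), so only a floor can be read here, and that floor does not clear the scatter. The earlier compounds showed only a large exchange of this group that stayed within the scatter, whereas this pair shows that a change in attachment alone, with the same atoms, can take a compound to the limit of the read-out, where it stands alone among the compounds shown: the limit of > 200000 nM in this assay, at which 1 of the 4 values shown sits.

The compounds shown leave open whether compound 4 truly differs from compound 2 by more than the scatter, as no number exists for compound 4. Also open, going by these compounds, is how a pyridin-2-yl group or a phenyl ring bearing a carboxylic acid would read at this place, and whether the same pyridine exchange would give a similar result on the core of compound 1.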